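Adding a Phenyl Next to the Ring Nitrogen

The source may report more compounds than this note shows. Statements on the series, on what has been measured and on what is new or still open speak of the compounds shown alone.

Compound 1 `Cn1nc(CCCO[Si](c2ccccc2)(c2ccccc2)C(C)(C)C)ccc1=O`: > 100000 nM
Compound 2 `O=c1ccc(CCCOCc2ccccc2)nn1Cc1ccccc1`: 32500 nM
Compound 3 `Cn1nc(CCCOCc2ccccc2)ccc1=O`: 76400 nM

In a functional assay on aorta (Rattus norvegicus) (a higher number here means a weaker inhibitor, a lower number a stronger inhibitor), compound 1 gives only a limit, > 100000 nM, and no number (the limit of > 100000 nM in this assay, at which 1 of the 3 values shown sits). Compound 3 gives 76400 nM, and compound 2 gives 32500 nM. The change from compound 3 to compound 2 is phenyl in place of hydrogen on a saturated chain carbon bound to an aromatic nitrogen, and it produced a 2.4-fold lower number from compound 3 to compound 2 (0.37 log units; beyond the scatter). The same change leads from compound 1 to compound 4 `CC(C)(C)[Si](OCCCc1ccc(=O)n(Cc2ccccc2)n1)(c1ccccc1)c1ccccc1`: phenyl in place of hydrogen on a saturated chain carbon bound to an aromatic nitrogen. The difference between the core of compound 1 and the core of compound 3 is not broken down here. Resting on the step from compound 3 to compound 2, compound 4 is expected to move by about a number no higher from compound 1 to compound 4 (the limit leaves the size open) from compound 1, but since compound 1 shows only a limit, the estimate is uncertain. Compound 4 is estimated at 100000 nM, between 30000 nM and 300000 nM.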

Compound 4, half-maximal inhibitory concentration: 39900 nM
Compound 4: middle estimate off by 2.5-fold (0.40 log units), on the high side; low and high end bracket the measured number.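

Replacing methyl with benzyl on the core of compound 1 also lowers the number in this assay (an at least 2.5-fold lower number from compound 1 to compound 4 (0.39 log units; beyond the scatter)). The change therefore points the same way on both cores shown, and the two steps can be set side by side: the same change on two cores in this assay, a 2.4-fold lower number (0.37 log units; beyond the scatter) from compound 3 to compound 2 and an at least 2.5-fold lower number (0.39 log units; beyond the scatter) from compound 1 to compound 4; the limit leaves it open whether they differ

From the compounds shown here alone, compound 1 gives > 100000 nM as a limit and not a number, and the true size of the step on its core stays unknown, as does whether it matches the step on the other core.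

Only methyl and benzyl appear at this place, which leaves open how a longer chain, an amine or a carboxylic acid there would read in this assay and whether the trend would hold. Two cores are also too few to show that the change carries over to the wider series.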